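Series notes: methylene substituent swap on the shared core

The source may hold more compounds than are shown below. What is called first, only, known or untested is meant among the compounds shown, and "the series" means these compounds.

Measured so far:
compound 1, `Fc1cccc(-c2nn3c(Cc4ccccc4F)nnc3s2)c1`, 25%
compound 2, `Fc1cccc(-c2nn3c(CN4CCCCC4)nnc3s2)c1`, 6%

Compound 2 stands lowest of the two numbers in an assay for inhibition of histone-lysine N-methyltransferase, H3 lysine-79 specific (Homo sapiens), with stated times of 15 min and 120 min, tested at 50 uM; on this read-out higher numbers stand for more inhibition at the one concentration tested (going by the name of the read-out) and lower numbers for less inhibition; its nearest neighbour is compound 1, and the step of a number 19 percentage points lower from compound 1 to compound 2 (beyond the scatter) lies beyond the scatter. Compound 3, `Cc1ccccc1Cc1nnc2sc(-c3cccc(F)c3)nn12`, is not yet measured. It differs from compound 2 by 2-methylphenyl in place of piperidin-1-yl on a saturated chain carbon bound to an aromatic carbon. For the measured compounds named here, the only measured step that bears on this change is a number 19 percentage points lower from compound 1 to compound 2 (beyond the scatter), where 2-fluorophenyl gave way to piperidin-1-yl at the same place and the number fell modestly. Compound 3 reverses that exchange in kind, putting an aromatic ring back where compound 1 carries 2-fluorophenyl, so a step upward is expected, roughly undoing the earlier loss: a number 16 percentage points higher from compound 2 to compound 3 (beyond the scatter). For compound 3 the estimate in this assay is 22%, with a range from 8% to 38%.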

Compound 3, a percentage reported as inhibition, at one concentration (the size of the read-out at that concentration, not a potency): 27%
Compound 3: middle estimate off by 5 percentage points, on the low side; the measured number falls inside the stated range.
By their numbers in this assay, from the lowest: compound 2; then compounds 1 and 3 (each within the scatter of the next).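

In this assay the step of a number 21 percentage points higher from compound 2 to compound 3 (beyond the scatter) shows that the drop seen with piperidin-1-yl on a saturated chain carbon bound to an aromatic carbon does not hold for the second aromatic group tried there, and 2-methylphenyl restores the number. For the compounds shown here, the step of a number 2 percentage points higher from compound 1 to compound 3 (within the scatter) is the first comparison of two aromatic groups at this place, and methyl in place of fluoro on an aromatic carbon leaves the two compounds within the scatter of each other. Nothing measured here explains why the non-aromatic ring and the aromatic rings part in this way.

Still open, from the compounds shown here alone, is how an unsubstituted phenyl, a morpholine or a primary amine would read at the same chain carbon. A longer chain carrying the 2-methylphenyl also remains untested in the compounds shown.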